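A Methyl-to-Hydroxymethyl Step on a Lipoxygenase Inhibitor Scaffold

This account rests on a few compounds, and the source may have more. Where it says the series, first, only, none or still open, it means among the compounds named here.

Measured so far:
- compound 1, `Cc1ccccc1N1CCCC(=O)N1`: 57000 nM
- compound 2, `Cc1cccc(N2CCCC(=O)N2)c1`: 3400 nM

Two compounds share a core and differ only in where a methyl group sits on the aromatic ring. In an assay on isolated protein for inhibition of Polyunsaturated fatty acid 5-lipoxygenase (Homo sapiens) (on this read-out lower numbers stand for stronger inhibition and higher numbers for weaker inhibition), compound 1 gives 57000 nM, while compound 2 gives 3400 nM, the lower of the two numbers, and the gap between them lies beyond the usual scatter of repeated measurements. Compound 2 is therefore the stronger of the two measured inhibitors.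

Compound 3, `O=C1CCCN(c2cccc(CO)c2)N1`, is the next step from compound 2. The change is hydroxy in place of hydrogen on a saturated chain carbon bound to an aromatic carbon; taken one bond further out, it reads as methyl to hydroxymethyl. For the measured compounds named here, no measured pair in this set shows such a change, so its effect is unknown here. The step from compound 2 to compound 3 is expected to be small, a 1.1-fold lower number from compound 2 to compound 3 (0.05 log units; within the scatter), with no clear direction beyond the scatter. Compound 3 is thus estimated at 3000 nM, within a range of 1000 nM to 10000 nM.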

Compound 3, half-maximal inhibitory concentration: 53000 nM
Beside the measured number, compound 3's estimate is 18-fold (1.25 log units) below it, outside the stated range (above it).
By their numbers in this assay, from the lowest: compound 2; then compounds 3 and 1 (each within the scatter of the next).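

Placing hydroxy on a saturated chain carbon bound to an aromatic carbon, the change that reads as methyl to hydroxymethyl, gives a 16-fold higher number from compound 2 to compound 3 (1.19 log units; beyond the scatter) in this assay. The earlier compounds shown here tied the number only to where the methyl group sits on the aromatic ring; this step shows that the number also responds strongly to a change of 1 heavy atom on that methyl group. Nothing available here explains this large step.

As far as these compounds go, it remains open whether other groups in place of hydroxymethyl, such as an aminomethyl group, a methoxymethyl group, a carboxylic acid or a longer hydroxyethyl chain, would give a similar number. From the compounds shown here alone, it is also open whether hydroxymethyl would have a similar effect at the ring position that the methyl group holds in compound 1.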